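Fluoro in place of methyl: compound 3 to compound 4

The source may hold more compounds than are shown below. What is called first, only, known or untested is meant among the compounds shown, and "the series" means these compounds.

In a functional assay on A549 cells (Homo sapiens) for inhibition, read by sulforhodamine B assay, with a stated time of 48 h (a lower number here means a stronger inhibitor, a higher number a weaker inhibitor), three structurally different compounds have been measured so far. Compound 1 (`CCOC(=O)CCO/N=C(/c1ccc(OC)c(OC)c1OC)c1cccc2ccccc12`) gives 19600 nM and compound 2 (`COc1ccc(C(c2ccc(OC(C)CN(C)C)cc2)c2cccc3ccccc23)c(OC)c1OC`) gives 11400 nM in the same read-out. Compound 3 (`COc1ccc(C(O)(Cc2ccc(C)cc2)c2cccc3ccccc23)c(OC)c1OC`) gives 18700 nM and stands within the scatter of both compound 1 and compound 2, so these numbers set no order among them.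

Compound 4 (`COc1ccc(C(O)(Cc2ccc(F)cc2)c2cccc3ccccc23)c(OC)c1OC`) departs from compound 3 at a single place: fluoro in place of methyl on an aromatic carbon (fluoro in place of methyl on an aromatic carbon, para to a large group, or 4-methylbenzyl to 4-fluorobenzyl). For the measured compounds named here, no pair of measured compounds differs in only one place, so the data hold no direct measure of this exchange or of any other single change. Going by the values given here, the only guide is the close neighbour, compound 3 at 18700 nM as the starting point, together with the narrow spread of the three numbers. No shift beyond the scatter is expected, and no firm direction can be assigned. The expected step of a 1.2-fold lower number from compound 3 to compound 4 (0.07 log units; within the scatter) is estimated to remain within the scatter. Compound 4 is estimated at 16000 nM with an expected range from 7500 nM to 32000 nM as its bounds.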

Compound 4, half-maximal inhibitory concentration: 5940 nM
Beside the measured number, compound 4's estimate is 2.7-fold (0.43 log units) above it; measured number outside the range, below it.
By their numbers in this assay, from the lowest: compounds 4, 2, 3 and 1 (each within the scatter of the next, the first and the last beyond it).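

For the compounds shown here, the exchange of methyl for fluoro on an aromatic carbon, para to a large group, is the first single-place change that can be read. In this assay it gives a 3.1-fold lower number from compound 3 to compound 4 (0.50 log units; beyond the scatter) and so shows that the group at this place on the 4-methylbenzyl side of compound 3 affects the number. Going by these compounds alone, the three earlier compounds could not show this, as no two of them differ in only one place and their numbers all lie within the scatter of each other. No measurement shown gives a reason for the step or says which feature of the exchange carries it.

Within the data shown here, with only this one pair, it remains open whether the step belongs to fluoro specifically or would follow from other replacements of methyl, such as chloro, methoxy, trifluoromethyl or a plain hydrogen at the same place. Also open, from the compounds shown here alone, are how an amine or a carboxylic acid at this place would read, and whether the same exchange would give a step of similar size on a different core.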